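The compounds below may be only part of what the source reports. "The series", "measured", "known", "first", "only" and "open" are said of these compounds alone.

Measured so far:
compound 1 `COc1ccc(S(=O)(=O)N2CCc3cccc(-c4cccs4)c32)cc1` – 215 nM
compound 2 `COc1ccc(S(=O)(=O)N2CCc3cccc(-c4ccccc4)c32)cc1` – 120 nM

Both values come from a functional assay on KB cells (Homo sapiens) for inhibition, with a stated time of 72 h; a lower number here means a stronger inhibitor, a higher number a weaker inhibitor. Going by the values given here, compound 2 gives the lowest of the two numbers, but its nearest neighbour is compound 1, and the one step between them, a 1.8-fold lower number from compound 1 to compound 2 (0.25 log units; within the scatter), is within the scatter, so the two compounds cannot be ranked against each other.

The next compound, compound 3 `COc1ccc(S(=O)(=O)N2CCc3cccc(-c4ccco4)c32)cc1`, has not been measured. It differs from compound 2 in one place: furan-2-yl in place of phenyl on an aromatic carbon. Among the compounds with values here, the only step that bears on this change is the one that swapped thiophen-2-yl for phenyl on the same aromatic carbon, a 1.8-fold lower number from compound 1 to compound 2 (0.25 log units; within the scatter), and that step stayed within the scatter. Since a five-membered aromatic ring with one hetero atom is again put in place of phenyl, no step beyond the scatter is expected in this assay, though the number may drift back toward that of compound 1.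

For compound 3 in this assay the expected value is 190 nM, with a range from 70 nM to 550 nM. The step this expectation means is a 1.6-fold higher number from compound 2 to compound 3 (0.20 log units; within the scatter).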

Compound 3, half-maximal inhibitory concentration: 82 nM
Compound 3: middle estimate off by 2.3-fold (0.36 log units), on the high side; the measured number falls inside the stated range.
By their numbers in this assay, from the lowest: compounds 3, 2 and 1 (each within the scatter of the next, the first and the last beyond it).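

In this assay, the step of a 1.5-fold lower number from compound 2 to compound 3 (0.17 log units; within the scatter) shows that furan-2-yl, a smaller ring with one hydrogen-bond acceptor, can stand in for phenyl on this aromatic carbon without a difference that can be read. Going by these compounds alone, the step of a 2.6-fold lower number from compound 1 to compound 3 (0.42 log units; beyond the scatter) is the first at this position to pass beyond the scatter, though only modestly, so the position does tell apart two five-membered aromatic rings with one hetero atom, even though phenyl cannot be ranked against either of them. Nothing measured here gives a reason for the difference between furan-2-yl and thiophen-2-yl.

Going by these compounds, all three compounds carry an aromatic ring at this place, so it stays open what an amine, a carboxylic acid or a longer alkyl chain would do on the same carbon. It is also open whether furan-3-yl or a pyridine ring would follow furan-2-yl, and whether the gap between furan-2-yl and thiophen-2-yl would hold on anything other than the shared core of these compounds.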